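The source may report more compounds than this note shows. Statements on the series, on what has been measured and on what is new or still open speak of the compounds shown alone.

Of the compounds shown here, three sharing one core have been tested in an ADME assay on MT4 cells (Homo sapiens) for cytotoxicity, read by MTT assay, with a stated time of 5 days (a higher number here means that more compound is tolerated, a lower number that less compound is tolerated), and they differ only in the single group on one aromatic carbon. Compound 1 `Cc1cc(C)c(Oc2cc(Nc3ccc(C#N)cc3)[nH]c(=O)c2I)c(C)c1`, the iodo member, gives 34000 nM. Compound 2 `Cc1cc(C)c(Oc2cc(Nc3ccc(C#N)cc3)[nH]c(=O)c2)c(C)c1`, with hydrogen on that carbon, gives 32000 nM. Compound 3 `Cc1cc(C)c(Oc2cc(Nc3ccc(C#N)cc3)[nH]c(=O)c2Cl)c(C)c1`, the chloro member, gives > 329000 nM, which is a limit and not a measured number. Even so, compound 3 is the best tolerated of the three.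

The next compound, compound 4 `Cc1cc(C)c(Oc2cc(Nc3ccc(C#N)cc3)[nH]c(=O)c2Br)c(C)c1`, makes one change to compound 3: bromo in place of chloro on an aromatic carbon. That is bromo in place of chloro on an aromatic carbon.

Among the measured compounds shown here, three measured steps bear on this. The swap of iodo for hydrogen gives a 1.1-fold lower number from compound 1 to compound 2 (0.03 log units; within the scatter). Chloro stands apart from both neighbours, with an at least 9.6-fold higher number from compound 1 to compound 3 (0.98 log units; beyond the scatter) and an at least 10-fold higher number from compound 2 to compound 3 (1.01 log units; beyond the scatter). The data do not show whether bromo behaves like chloro or like iodo, so a drop is expected, but its size is uncertain. Given the large gaps in an at least 9.6-fold higher number from compound 1 to compound 3 (0.98 log units; beyond the scatter) and an at least 10-fold higher number from compound 2 to compound 3 (1.01 log units; beyond the scatter), the expected change in this assay is an at least 3.6-fold lower number from compound 3 to compound 4 (0.56 log units; beyond the scatter), and compound 4 may still reach a limit. The estimated value for compound 4 is 90000 nM, with an expected range from 25000 nM to 350000 nM.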

Compound 4, half-maximal cytotoxic concentration: > 294000 nM
Compound 4 gave a limit, no number; the forecaster's own chance of this, stated with the estimate: 35%; middle value at least 3.2-fold (0.51 log units) from the limit.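

In this assay bromo on this carbon sits with chloro and not with hydrogen or iodo, with an at least 9.1-fold higher number from compound 2 to compound 4 (0.96 log units; beyond the scatter) and with an at least 8.6-fold higher number from compound 1 to compound 4 (0.93 log units; beyond the scatter) as the two readable steps. The high tolerance at this position is therefore not a feature of chloro alone, yet iodo goes against any rule for halogens in general, since compound 1 stays within the scatter of compound 2, which carries only hydrogen here. Compound 4 ends in a limit, as compound 3 does, and the step between them cannot be read because neither value is a measured number: the limit of > 294000 nM in this assay, at which 1 of the 4 values shown sits.

The compounds shown leave open how far compound 3 and compound 4 really lie from each other, and so whether chloro and bromo differ at all in this assay once both can be measured. They also leave open what fluoro, methyl, an amine or a carboxylic acid on this same carbon would give, and whether the gap between bromo and iodo would survive a change elsewhere in the shared core.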